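The compounds below may be only part of what the source reports. "The series", "measured", "known", "first", "only" and "open" are said of these compounds alone.

Measured in an ADME assay on HepG2 2.2.15 cells (Homo sapiens) for cytotoxicity; a lower number here means that less compound is tolerated, a higher number that more compound is tolerated:
- compound 1 `Cn1c(=O)c(CCO)c(-c2ccccc2Cl)c2cc(Cl)ccc21`: 34000 nM
- compound 2 `O=c1c(CCO)c(-c2ccccc2Cl)c2cc(Cl)ccc2n1-c1c(F)cccc1F`: > 2300000 nM
- compound 3 `CCCC(=O)OCCc1c(-c2ccccc2Cl)c2cc(Cl)ccc2[nH]c1=O`: 52000 nM

The entry for compound 2, > 2300000 nM, is a limit of the assay and not a number. Compound 1, at 34000 nM, and compound 3, at 52000 nM, lie within the scatter of each other.

Compound 4 `CC(=O)NCC(=O)OCCc1c(-c2ccccc2Cl)c2cc(Cl)ccc2[nH]c1=O` departs from compound 3 by one change: acetamido in place of ethyl on a saturated chain carbon bound to a carbonyl carbon.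

For the measured compounds named here, only one measured step exists, an at least 67-fold higher number from compound 1 to compound 2 (1.83 log units; beyond the scatter). It is large, but it lies at a different place in the structure and ends at a limit, so it gives no guide to the size or direction of this change. Going by the values given here, no measured step touches the chain that changes here. The expectation therefore stays close to compound 3 at 52000 nM, with no shift beyond the scatter in this assay.

The expected step is a 1.2-fold higher number from compound 3 to compound 4 (0.06 log units; within the scatter).

For compound 4 the estimate is 60000 nM, with an expected range of 22000 nM to 180000 nM.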

Compound 4, half-maximal cytotoxic concentration: 110000 nM
Compound 4: the middle estimate sits 1.8-fold (0.26 log units) below what was measured; low and high end bracket the measured number.
By their numbers in this assay, from the lowest: compounds 1 and 3 (each within the scatter of the next); then compound 4. At a limit, above all of these: compound 2.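

In this assay, acetamido in place of ethyl on a saturated chain carbon bound to a carbonyl carbon gives a 2.1-fold higher number from compound 3 to compound 4 (0.33 log units; beyond the scatter). For the compounds shown here, this is the first measured step at this place, and it shows that the chain can shift the number beyond the scatter, although only modestly; the one earlier step lay on the aromatic nitrogen and ended at a limit. Nothing measured here accounts for this step. The compounds shown leave open whether an amine, a carboxylic acid or a longer chain at this place would move the number further, or in the opposite direction. Also open, going by these compounds, is how this change would read with a substituent on the aromatic nitrogen: compound 2 has a limit of > 2300000 nM, which is not a number.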